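Methoxy Addition Across Two Related Cores

This account rests on a few compounds, and the source may have more. Where it says the series, first, only, none or still open, it means among the compounds named here.

Compound 1 `COc1ccc(/C=C/C2CC=CC(=O)O2)cc1OC` and compound 2 `COc1cc(OC)c(OC)cc1/C=C/C1CC=CC(=O)O1` share one core; compound 3 `COc1ccc(/C=C/C2CC=CC(=O)N2)cc1` and compound 4 `COc1ccc(/C=C/C2CC=CC(=O)N2)c(OC)c1` share another, and the difference between the two cores is not broken down here. In a functional assay on NCI-H460 cells (Homo sapiens) for inhibition, read by sulforhodamine B assay, with a stated time of 48 h (a lower number here means a stronger inhibitor of growth, a higher number a weaker inhibitor of growth), compound 1 gives 14.6 uM and compound 2 gives 9.8 uM. The change from compound 1 to compound 2, (methoxy in place of hydrogen on an aromatic carbon), produced a 1.5-fold lower number from compound 1 to compound 2 (0.17 log units; within the scatter). Compound 3 reaches only a limit of this assay, > 1090 uM, sitting at the limit of > 1090 uM in this assay, at which 1 of the 3 values shown sits. Compound 4 differs from compound 3 by methoxy in place of hydrogen on an aromatic carbon, the same kind of change, though here the place is not also para to a methoxy group. Because the earlier step of a 1.5-fold lower number from compound 1 to compound 2 (0.17 log units; within the scatter) stayed within the scatter, compound 4 is expected to remain near that limit, a step that the limit leaves unreadable from compound 3 to compound 4. The estimate for compound 4 is 1500 uM, and this assay may again report only a limit.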

Compound 4, concentration for growth inhibition (reported as GI): > 964 uM
Compound 4: no number, only a limit; the forecaster's own chance of this, stated with the estimate: 75%; the middle value is on the limit's open side.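

Compound 3 and compound 4 each give only a limit rather than a number, so the step between them cannot be read. On these data alone, whether methoxy in place of hydrogen changes growth inhibition on this core remains open.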